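The compounds below may be only part of what the source reports. "The series", "measured", "known", "first", "only" and "open" are said of these compounds alone.

The study examines antagonists of the glucagon receptor built on a shared spiro core, and it turns on the step from compound 1 to compound 4. Of the compounds shown here, three carry numbers so far. Compound 1 `CC(C)(C)CC[C@H](c1ccc(C(=O)NCc2nn[nH]n2)cc1)N1C(=O)C(c2cncc(Cl)c2)=N[C@]12CC[C@@H](C(C)(C)C)CC2` gives, in a functional assay on CHO cells for antagonist activity at Glucagon receptor (Homo sapiens), read by cAMP accumulation, with stated times of 30 min and 45 min (a lower number here means a stronger inhibitor, a higher number a weaker inhibitor), 480 nM. Compound 2 `CC(C)(C)[C@H]1CC[C@]2(CC1)N=C(c1cccc(C(F)(F)F)c1)C(=O)N2Cc1ccc(C(=O)NCCC(=O)O)cc1` gives in this assay 510 nM, and compound 3 `C[C@H](c1ccc(C(=O)NCCC(=O)O)cc1)N1C(=O)C(c2cccc(F)c2)=N[C@]12CC[C@@H](C(C)(C)C)CC2` gives in this assay 560 nM. The three numbers sit close together: the gap from compound 1 to compound 2, like that to compound 3, lies within the usual scatter, so none of the three can be set apart from the others on these data.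

Compound 4 `CC(C)(C)CC[C@H](c1ccc(C(=O)NCc2nn[nH]n2)cc1)N1C(=O)C(c2ccc(F)cc2)=N[C@]12CC[C@@H](C(C)(C)C)CC2` has not yet been measured. It differs from compound 1 in one place: 4-fluorophenyl in place of 5-chloropyridin-3-yl on a carbon with a double bond to nitrogen. Among the compounds with values here, no pair of measured compounds isolates this change, so the size of its effect is unknown. Given that compound 1 shows 480 nM, compound 4 is expected to give 600 nM, within a range from 250 nM to 1500 nM. The expected step of a 1.3-fold higher number from compound 1 to compound 4 (0.10 log units; within the scatter) is estimated to be small, at most a mild weakening barely beyond the scatter.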

Compound 4, half-maximal inhibitory concentration: 240 nM
Estimate against measurement, compound 4: 2.5-fold (0.40 log units) above; the whole stated range lies above it.
By their numbers in this assay, from the lowest: compounds 4, 1, 2 and 3 (each within the scatter of the next, the first and the last beyond it).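

At the carbon with a double bond to nitrogen, 4-fluorophenyl in place of 5-chloropyridin-3-yl gives, in this assay, a 2.0-fold lower number from compound 1 to compound 4 (0.30 log units; within the scatter), so this single exchange cannot be told apart from repeat measurement. The ring that enters is carbon only and has no hydrogen-bond acceptor, so in this pair neither the ring nitrogen nor the chlorine of compound 1 is needed to keep the number at this level. No measurement on hand bears on why the two rings give such similar numbers.

The compounds shown leave open whether a phenyl ring carrying an amine or a nitrile would also stay within the scatter of compound 4 at this carbon. They also leave open whether a longer alkyl chain could replace the ring there altogether.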